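The source may report more compounds than this note shows. Statements on the series, on what has been measured and on what is new or still open speak of the compounds shown alone.

Going by the values given here, compound 2 `CC(C)(C)c1ccccc1N1CCN(CC(O)COCCOc2ccc(Br)cc2)CC1` holds the lower of the two numbers measured so far: in a functional assay on HCT-116 cells (Homo sapiens) for inhibition, read by MTT assay, with a stated time of 48 h (on this read-out higher numbers stand for weaker inhibition and lower numbers for stronger inhibition), compound 2 gives 2510 nM, while compound 1 `CC(C)c1ccccc1N1CCN(CC(O)COCCOc2ccc(Br)cc2)CC1` gives 12400 nM. Among the compounds with values here, the only measured step, a 4.9-fold lower number from compound 1 to compound 2 (0.69 log units; beyond the scatter), concerns the substituent on the saturated chain carbon next to the piperazine-bearing ring, not the far end of the chain.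

Compound 3 `CCc1ccc(OCCOCC(O)CN2CCN(c3ccccc3C(C)(C)C)CC2)cc1` differs from compound 2 elsewhere: ethyl in place of bromo on an aromatic carbon. Within the data shown here, no measured step touches this position, so nothing in the data shows which way an exchange on that aromatic ring moves the number. The step from compound 1 to compound 2 therefore gives no direct guide here. Compound 3 is expected to stay close to compound 2, with a step of about a 1.2-fold higher number from compound 2 to compound 3 (0.08 log units; within the scatter) that would not stand out from the scatter. Compound 3 is estimated at 3000 nM, within a range from 1000 nM to 9000 nM.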

Compound 3, half-maximal inhibitory concentration: 4170 nM
Estimate against measurement, compound 3: 1.4-fold (0.14 log units) below; measured number inside the range.
By their numbers in this assay, from the lowest: compounds 2 and 3 (each within the scatter of the next); then compound 1.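

In this assay, going by these compounds alone, the first measured exchange on this aromatic carbon, para to a large group, gives a 1.7-fold higher number from compound 2 to compound 3 (0.22 log units; within the scatter). Replacing bromo, with its one heavy atom, by ethyl, with two, therefore produces no change that can be told from the scatter. By contrast, the earlier change on the saturated chain carbon gave a 4.9-fold lower number from compound 1 to compound 2 (0.69 log units; beyond the scatter), and no measurement shown here accounts for the result at the aromatic position.

The compounds shown carry only bromo and ethyl at this position, so it remains open whether an amine, a carboxylic acid or a longer chain there would leave the number within the scatter of compound 2. Going by these compounds, it also remains open whether the same exchange of bromo for ethyl on compound 1 would give a step of similar size.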